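Notes: acetyl in place of methyl on compound 3

This account rests on a few compounds, and the source may have more. Where it says the series, first, only, none or still open, it means among the compounds named here.

All values below come from a functional assay on MV4-11 cells (Homo sapiens) for inhibition, read by luminescence, with a stated time of 3 days (on this read-out higher numbers stand for weaker inhibition of growth and lower numbers for stronger inhibition of growth), and no other read-out.

compound 1 `CC(C)C1=C(C(=O)N2[C@H](C)CC[C@H]2C(=O)N2CCN(C)CC2)SC2=N[C@@](C)(c3ccc(Cl)cc3)[C@@H](c3ccc(Cl)cc3)N21` gives 190 nM
compound 2 `CC(=O)N1CCN(C(=O)[C@@H]2CC[C@@H](C)N2C(=O)C2=C(C(C)C)N3C(=N[C@@](C)(c4ccc(Cl)cc4)[C@H]3c3ccc(Cl)cc3)S2)CC1` gives 270 nM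
compound 3 `CC[C@@H]1CC[C@@H](C(=O)N2CCN(C)CC2)N1C(=O)C1=C(C(C)C)N2C(=N[C@@](C)(c3ccc(Cl)cc3)[C@H]2c2ccc(Cl)cc2)S1` gives 83 nM

Compound 3 holds the lowest number of the three, with gaps to compound 1 and compound 2 beyond the scatter. Compound 4 `CC[C@@H]1CC[C@@H](C(=O)N2CCN(C(C)=O)CC2)N1C(=O)C1=C(C(C)C)N2C(=N[C@@](C)(c3ccc(Cl)cc3)[C@H]2c2ccc(Cl)cc2)S1` differs from it by acetyl in place of methyl on an amine nitrogen in a ring, counted as acetyl in place of methyl on an amine nitrogen in a ring in full. The same swap has one measured precedent, a 1.4-fold higher number from compound 1 to compound 2 (0.15 log units; within the scatter) and so no clear change. The step of a 2.3-fold lower number from compound 1 to compound 3 (0.36 log units; beyond the scatter) lies at another place and does not bear on this swap directly. In this assay a small step toward a higher number is therefore expected, probably not clearly beyond the scatter. The expected step is a 1.4-fold higher number from compound 3 to compound 4 (0.14 log units; within the scatter) by this estimate. For compound 4 the estimated value is 115 nM with an expected range from 60 nM to 220 nM on this basis.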

Compound 4, concentration for 50% growth inhibition: 130 nM
Estimate against measurement, compound 4: 1.1-fold (0.05 log units) below, and the stated range covers the measured number.
By their numbers in this assay, from the lowest: compounds 3, 4, 1 and 2 (each within the scatter of the next, the first and the last beyond it).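

In this assay, the change from 4-methylpiperazin-1-yl to 4-acetylpiperazin-1-yl now has a second reading, a 1.6-fold higher number from compound 3 to compound 4 (0.19 log units; within the scatter), so the absence of a clear change is not confined to one core: the same change on two cores in this assay, a 1.4-fold higher number (0.15 log units; within the scatter) from compound 1 to compound 2 and a 1.6-fold higher number (0.19 log units; within the scatter) from compound 3 to compound 4, 1.1-fold (0.04 log units) apart, within the scatter of two such steps

The methyl in place of hydrogen on the saturated chain carbon also keeps its modest step with acetyl on the ring nitrogen, a 2.1-fold lower number from compound 2 to compound 4 (0.32 log units; beyond the scatter): the same change on two cores in this assay, a 2.3-fold lower number (0.36 log units; beyond the scatter) from compound 1 to compound 3 and a 2.1-fold lower number (0.32 log units; beyond the scatter) from compound 2 to compound 4, 1.1-fold (0.04 log units) apart, within the scatter of two such steps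

Across these four compounds, the two changes therefore read as independent of each other.

Open, on these data alone, is how a free amine, a carboxylic acid or a longer acyl chain on that ring nitrogen would read in this assay.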